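The source may report more compounds than this note shows. Statements on the series, on what has been measured and on what is new or still open speak of the compounds shown alone.

Of the compounds shown here, two built on a shared core have been tested in a functional assay on KB cells (Homo sapiens) for antiproliferative activity, read by sulforhodamine B assay, with a stated time of 72 h; a lower number here means a stronger inhibitor of growth, a higher number a weaker inhibitor of growth. Compound 1 `Cc1cc(=O)oc2cc(SCc3ccccn3)ccc12` gives only a limit of the assay in this assay, > 35200 nM. Compound 2 `Cc1cc(=O)oc2cc(SCc3cccc(C#N)c3)ccc12` likewise gives only a limit in this assay, > 32500 nM. Compound 2 thus stands at one of the two limits shown; neither compound yields a number, so no order between them can be stated. The unmeasured compound 3 `Cc1cccc(CSc2ccc3c(C)cc(=O)oc3c2)c1` differs from compound 2 by a single exchange, (methyl in place of cyano on an aromatic carbon), in words methyl in place of cyano on an aromatic carbon. Among the measured compounds shown here, no step between measured compounds exists to gauge what such an exchange does here. Because compound 2 sits at a limit (the limit of > 32500 nM in this assay, at which 1 of the 2 values shown sits), a gain could only appear if compound 3 fell clearly into the range where a number is read. Compound 1 offers no hint of that either, as its value is also a limit (the limit of > 35200 nM in this assay, at which 1 of the 2 values shown sits). The expected step from compound 2 to compound 3 is therefore a step that the limit leaves unreadable from compound 2 to compound 3, nothing beyond the scatter. Compound 3 is expected to give about 40000 nM in this assay, between 10000 nM and 150000 nM.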

Compound 3, concentration for 50% growth inhibition: > 33700 nM
Compound 3 ended at the assay's limit; the forecaster's own chance of this, stated with the estimate: 85%; the middle value lies beyond the limit too.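

Among the compounds shown here, compound 3, like compound 1 and compound 2, gives only a limit in this assay, so no step from compound 1 or compound 2 to compound 3 can be read. The compounds shown leave open whether any change to the groups on the shared core would give a growth-inhibiting concentration that can be read as a number.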